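This account rests on a few compounds, and the source may have more. Where it says the series, first, only, none or still open, it means among the compounds named here.

Of the compounds shown here, two have a measured number so far. In an assay on isolated protein for inhibition of DNA topoisomerase 1 (Homo sapiens), with a stated time of 30 min, tested at 100 uM (a lower number here means a weaker effect, a higher number a stronger effect of the compound at the concentration tested), compound 1 `Oc1cccc(-c2cc(-c3ccco3)cc(-c3ccccc3O)n2)c1` gives 90.1%. Compound 2 `Oc1ccccc1-c1cc(-c2cccnc2)cc(-c2ccccc2O)n1` gives 66.4% in this assay, the lower of the two numbers and a gap beyond the usual scatter from compound 1; since these two structures differ in more than one place, the gap cannot be tied to a single change. Compound 3 `Oc1cccc(-c2cc(-c3cccnc3)cc(-c3ccccc3O)n2)c1` has not yet been measured. It differs from compound 2 in one place only: 3-hydroxyphenyl in place of 2-hydroxyphenyl on an aromatic carbon. Among the measured compounds shown here, with no single-change step known, the expected step of a number 9.6 percentage points higher from compound 2 to compound 3 (within the scatter) is a modest rise that may not clearly exceed the scatter, leaning upward because compound 1 with the same 3-hydroxyphenyl group gives 90.1%. For compound 3 the estimate in this assay is 76%, within a range from 56% to 92%.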

Compound 3, a percentage reported as inhibition, at one concentration (the size of the read-out at that concentration, not a potency): 1.9%
The estimate for compound 3 lay 74.1 percentage points above the measured number, and the stated range ends above it.
By their numbers in this assay, from the lowest: compound 3; then compound 2; then compound 1.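

In this assay, the aromatic carbon next to the ring nitrogen proves highly sensitive to how its substituent is joined: 3-hydroxyphenyl in place of 2-hydroxyphenyl, with the same atoms, gives a number 64.5 percentage points lower from compound 2 to compound 3 (beyond the scatter). The 3-hydroxyphenyl group therefore does not secure a high number by itself, since pyridin-3-yl in place of furan-2-yl on an aromatic carbon, with 3-hydroxyphenyl kept, gives a number 88.2 percentage points lower from compound 1 to compound 3 (beyond the scatter). The outcome of the 3-hydroxyphenyl group thus depends on the other group it is paired with in these compounds, and nothing available here explains either step.

The compounds shown leave open how furan-2-yl would read when paired with 2-hydroxyphenyl at this position in place of 3-hydroxyphenyl. They also leave open how 4-hydroxyphenyl, or a phenyl ring carrying a methoxy group or an amine instead of the hydroxyl, would read there.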